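Compound 3 and the pyridin-2-yl amide in cytotoxicity

A few compounds are considered here, and "the series" means these few. Any claim that something is new, unique, unknown or untested is made for them only; others in the source may bear on it.

In an ADME assay on LLC-MK2 cells (Macaca mulatta) for cytotoxicity, read by spectrophotometry and crystal violet staining, with a stated time of 4 days (on this read-out higher numbers stand for lower toxicity in this test and lower numbers for higher toxicity in this test), compound 1 (`CC(C)n1ncc2c(C(=O)Nc3ccncc3)cc(-c3cccs3)nc21`) gives 6300 nM as its reading. Compound 3 (`CC(C)n1ncc2c(C(=O)Nc3ccccc3S(N)(=O)=O)cc(-c3cccs3)nc21`) gives 25000 nM and holds the higher of these two numbers, with a 4.0-fold higher number from compound 1 to compound 3 (0.60 log units; beyond the scatter) as the step between them. Compound 2 (`CC(C)n1ncc2c(C(=O)Nc3c(F)cc(F)cc3F)cc(-c3cccs3)nc21`) reads > 200000 nM and this value is a limit of the assay. The other steps on the amide-type nitrogen are large or at least modest: an at least 31-fold higher number from compound 1 to compound 2 (1.50 log units; beyond the scatter) and an at least 8.0-fold lower number from compound 2 to compound 3 (0.90 log units; beyond the scatter) are both measured against that limit. Compound 4 (`CC(C)n1ncc2c(C(=O)Nc3ccccn3)cc(-c3cccs3)nc21`) differs from compound 3 by pyridin-2-yl in place of 2-sulfamoylphenyl on an amide-type nitrogen in one place, with pyridin-2-yl in place of 2-sulfamoylphenyl on an amide-type nitrogen. The nearest guide is compound 1 with its pyridin-4-yl group, at 6300 nM on the lower side of compound 3. The expected step is modest and towards a lower number, a 2.5-fold lower number from compound 3 to compound 4 (0.40 log units; beyond the scatter) by this estimate. Compound 4 is expected at 10000 nM with 3000 nM to 50000 nM as the likely range.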

Compound 4, half-maximal cytotoxic concentration: > 200000 nM
Compound 4: only a limit was reported (the forecaster's own chance of this, stated with the estimate: 5%); at least 20-fold (1.30 log units) between middle value and limit.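

On the amide-type nitrogen, exchanging one pyridine for its isomer is enough to move the reading in this assay: pyridin-2-yl in place of pyridin-4-yl gives an at least 31-fold higher number from compound 1 to compound 4 (1.50 log units; beyond the scatter) on this read-out. Pyridin-2-yl in place of 2-sulfamoylphenyl gives an at least 8.0-fold higher number from compound 3 to compound 4 (0.90 log units; beyond the scatter) at the same place. Compound 4 stands at a limit of the assay, and the step between it and compound 2 cannot be read: the limit of > 200000 nM in this assay, at which 2 of the 4 values shown sit.

On these data alone, how far compound 4 lies past its limit stays open. So does whether pyridin-3-yl on this nitrogen, or a pyridin-2-yl carrying an amine, would read with compound 1 or with compound 4.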